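Lengthening the chain substituent on the shared core

The source may hold more compounds than are shown below. What is called first, only, known or untested is meant among the compounds shown, and "the series" means these compounds.

Measured compounds:
compound 1, `C=CCc1ccccc1NCC1=NCCN1`, 0.8
compound 2, `Cc1ccccc1NCC1=NCCN1`, 0.8

In an assay on CHO cells for agonist activity at Alpha-2C adrenergic receptor (Homo sapiens), with a stated time of 240 min (on this read-out lower numbers stand for smaller maximal responses and higher numbers for larger maximal responses), compound 1 gives 0.8 and compound 2 gives 0.8, so the two stand level within the scatter. For the measured compounds named here, the one measured step, no change at the digits printed from compound 1 to compound 2 (within the scatter), shows that removing the vinyl from the chain carbon leaves the maximal response unchanged.

Compound 3, `CCCc1ccccc1NCC1=NCCN1`, has not yet been measured. It differs from compound 2 in one place: ethyl in place of hydrogen on a saturated chain carbon bound to an aromatic carbon. This change reverses the direction of the measured step, adding carbon to the same chain carbon rather than taking it away, and compound 3 can also be read as a saturated counterpart of compound 1, which sits level with compound 2. Because the step of no change at the digits printed from compound 1 to compound 2 (within the scatter) lay within the scatter, the size of substituent on this chain carbon appears, on the two compounds available, to have little bearing on the maximal response.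

Compound 3 is therefore expected to show no change at the digits printed from compound 2 to compound 3 (within the scatter) in this assay. The estimate for compound 3 is 0.8, with a range from 0.6 to 0.95.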

Compound 3, intrinsic activity: the largest response reached, as a fraction of the reference agonist's: 0.75
Estimate against measurement, compound 3: 0.050 above; low and high end bracket the measured number.
By their numbers in this assay, from the lowest: compounds 3, 1 and 2 (each within the scatter of the next).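

In this assay, the step with ethyl in place of hydrogen on a saturated chain carbon bound to an aromatic carbon is a number 0.050 lower from compound 2 to compound 3 (within the scatter), so the reading from the earlier pair now also holds for a saturated chain, with methyl and propyl standing level within the scatter. The comparison of ethyl in place of vinyl at the same place, which the earlier compounds could not offer, is a number 0.050 lower from compound 1 to compound 3 (within the scatter), so among these three compounds neither the size of this substituent nor the presence of its double bond separates the maximal responses. Nothing is available that would explain this flat reading.

The compounds shown span only methyl, propyl and a chain ending in vinyl, so they leave open whether a longer chain such as hexyl, a branched group such as isopropyl or a ring such as phenyl at this place would stay level too. They also leave open whether a chain ending in an amine or a carboxylic acid would hold the maximal response on the shared core.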